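The source may report more compounds than this note shows. Statements on the series, on what has been measured and on what is new or still open speak of the compounds shown alone.

Compound 1 `O=C(O)CNc1nc(-c2ccccc2)nc2ccc(Br)cc12` gives 0%.
Compound 2 `O=C(O)CNc1nc(-c2ccccc2)nc2ccc(I)cc12` gives 0%.
Compound 3 `C[C@H](Nc1nc(-c2ccccc2)nc2ccc(Br)cc12)C(=O)O` gives 0%.

All three compounds share one core and were tested in a functional assay on the whole organism (strain Wistar) for inhibition, with Rattus norvegicus as the target, read by paw edema, at a dose of 100 mg/kg by the oral route; a higher number here means more inhibition at the dose given (going by the name of the read-out), a lower number less inhibition. Compound 1 and compound 2 differ by iodo in place of bromo on an aromatic carbon, and the step reads no change at the digits printed from compound 1 to compound 2 (within the scatter). Compound 1 and compound 3 differ by methyl in place of hydrogen on a saturated chain carbon bound to a carbonyl carbon and a nitrogen on an aromatic ring, and the step reads no change at the digits printed from compound 1 to compound 3 (within the scatter). Compound 4 `C[C@H](Nc1nc(-c2ccccc2)nc2ccc(I)cc12)C(=O)O` has not yet been measured. It differs from compound 3 by iodo in place of bromo on an aromatic carbon, the same change as that between compound 1 and compound 2, at the same place. Compound 4 is expected to show no change at the digits printed from compound 3 to compound 4 (within the scatter) because no change at the digits printed from compound 1 to compound 2 (within the scatter). Compound 4 is therefore estimated at 0%, expected to fall between 0% and 10%.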

Compound 4, a percentage reported as inhibition, in the whole organism at one dose (the size of the read-out at that dose, not a potency): 6.5%
The estimate for compound 4 lay 6.5 percentage points below the measured number, and the stated range covers the measured number.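

In this assay, iodo in place of bromo on an aromatic carbon gives a number 6.5 percentage points higher from compound 3 to compound 4 (within the scatter), and this step agrees with the earlier one on the other core: the same change on two cores in this assay, no change at the digits printed (within the scatter) from compound 1 to compound 2 and a number 6.5 percentage points higher (within the scatter) from compound 3 to compound 4, 6.5 percentage points apart, within the scatter of two such steps Methyl in place of hydrogen on the saturated chain carbon gives a number 6.5 percentage points higher from compound 2 to compound 4 (within the scatter), and this step also agrees with its earlier counterpart: the same change on two cores in this assay, no change at the digits printed (within the scatter) from compound 1 to compound 3 and a number 6.5 percentage points higher (within the scatter) from compound 2 to compound 4, 6.5 percentage points apart, within the scatter of two such steps Neither change moves the read-out beyond the scatter on either core, but this does not show how either change would carry over to a core with clear inhibition at this dose.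

The compounds shown leave open what chloro or methoxy would do in place of the halogen. They also leave open the effect of an ester or amide in place of the carboxylic acid, or of a longer chain in place of the methyl.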